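The source may hold more compounds than are shown below. What is called first, only, known or untested is meant among the compounds shown, and "the series" means these compounds.

Three compounds share one core and were examined in an assay on CHO-K1 cells for displacement of a labelled ligand from prostaglandin E2 receptor EP1 subtype (Homo sapiens); a lower number here means a stronger inhibitor, a higher number a weaker inhibitor. Compound 1 `Cc1cc(NC(=O)C2CCCCC2)nn1Cc1cc(Cl)ccc1OCC(C)C` gives 31.6 nM, compound 2 `Cc1cc(NC(=O)C2CCCC2)nn1Cc1cc(Cl)ccc1OCC(C)C` gives 25.1 nM, and compound 3 `Cc1cc(NC(=O)OC(C)C)nn1Cc1cc(Cl)ccc1OCC(C)C` gives 50.1 nM. The steps among them are small: a 1.3-fold lower number from compound 1 to compound 2 (0.10 log units; within the scatter), a 1.6-fold higher number from compound 1 to compound 3 (0.20 log units; within the scatter) and a 2.0-fold higher number from compound 2 to compound 3 (0.30 log units; within the scatter). Compound 3 has the highest of the three numbers, yet each of its neighbours lies within the scatter of it, so no order can be read from these values.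

Compound 4 `Cc1cc(NC(=O)OC2CCOCC2)nn1Cc1cc(Cl)ccc1OCC(C)C` is not yet measured. It differs from compound 3 in one place: oxan-4-yl in place of isopropyl on an oxygen next to a carbonyl group. Among the measured compounds shown here, the steps that bear on this are those that swapped the group on the carbonyl carbon, from compound 1 and from compound 2 to compound 3, both within the scatter. On that basis only a small step is expected in this assay, a 1.0-fold lower number from compound 3 to compound 4 (0.00 log units; within the scatter), with no clear direction. Compound 4 is therefore estimated at 50 nM, expected to fall between 20 nM and 125 nM.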

Compound 4, half-maximal inhibitory concentration in the prostaglandin E2 receptor EP1 subtype assay: 63.1 nM
Compound 4: middle estimate off by 1.3-fold (0.10 log units), on the low side, within the range that was stated.
By their numbers in the prostaglandin E2 receptor EP1 subtype assay, from the lowest: compounds 2, 1, 3 and 4 (each within the scatter of the next, the first and the last beyond it).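

Among the compounds shown here, in the prostaglandin E2 receptor EP1 subtype assay, putting oxan-4-yl in place of isopropyl on this oxygen next to a carbonyl group gives a 1.3-fold higher number from compound 3 to compound 4 (0.10 log units; within the scatter) and so leaves the number within the scatter, as does the swap giving a 2.0-fold higher number from compound 1 to compound 4 (0.30 log units; within the scatter) while the swap giving a 2.5-fold higher number from compound 2 to compound 4 (0.40 log units; beyond the scatter) is the only step of the three that is modest and beyond it. In a physicochemical assay for lipophilicity, at pH 7.4 (a lower number here means a more polar compound, a higher number a more lipophilic compound), compound 3 gives only a limit, > 3.7 and not a number. In the physicochemical assay, compound 4 gives 3.4 as a number, so the change reads as a number at least 0.30 log units lower from compound 3 to compound 4 (that floor lies within the scatter) and its true size cannot be fixed: the limit of > 3.7 in the physicochemical assay, at which 1 of the 2 values shown sits.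

On these data alone, whether the step in the prostaglandin E2 receptor EP1 subtype assay would stay this small with an amine or a longer chain on the same oxygen remains open. A cyclohexyl group there would also be needed to tell the ring apart from its oxygen atom.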